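Bromo in place of nitro: working notes on toxicity

The compounds below may be only part of what the source reports. "The series", "measured", "known", "first", "only" and "open" are said of these compounds alone.

Measured so far in a toxicity assay on THP-1 cells (Homo sapiens) for inhibition; on this read-out lower numbers stand for higher toxicity in this test and higher numbers for lower toxicity in this test
- compound 1 `Cn1c(-c2ccc(F)cc2)cnc1NC(=O)c1ccc(F)cc1` gives > 100000 nM
- compound 2 `Cn1c(-c2cccc([N+](=O)[O-])c2)cnc1NC(=O)c1ccc(F)cc1` gives > 50000 nM

Compound 1 reaches only a limit, not a number. Compound 2 likewise gives > 50000 nM in this assay, and this too is a limit. No numerical value is therefore available for compound 2, and the two results cannot be placed in order. For the measured compounds named here, no measured step offers a size to carry forward.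

The next compound, compound 3 `Cn1c(-c2cccc(Br)c2)cnc1NC(=O)c1ccc(F)cc1`, has bromo in place of nitro on an aromatic carbon, meta to a large group (bromo in place of nitro on an aromatic carbon). The shared core and the fluorinated amide part stay unchanged.

No change beyond the scatter is expected in this assay, and no direction is favoured. This expectation rests on compound 1 with > 100000 nM, a limit. It rests equally on compound 2 with > 50000 nM, also a limit. The expected move is a step that the limit leaves unreadable from compound 2 to compound 3. A further limit is the likelier report. For compound 3 the estimated value is 60000 nM, with an expected range from 25000 nM to 120000 nM.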

Compound 3, half-maximal cytotoxic concentration: > 50000 nM
Compound 3: only a limit was reported; the forecaster's own chance of this, stated with the estimate: 70%; the middle value is on the limit's open side.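

In this assay compound 3 gives > 50000 nM, which is a limit. For the compounds shown here, all three results are limits, so no step from compound 1 or compound 2 to compound 3 can be read. The compounds shown leave open how bromo and nitro compare in this assay, and whether any of the three compounds has a measurable half-maximal cytotoxic concentration.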